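Trifluoromethyl in place of fluoro: compound 2 to compound 4

The compounds below may be only part of what the source reports. "The series", "measured", "known", "first", "only" and "open" are said of these compounds alone.

Compound 2 `Oc1cc(C(F)(F)F)ccc1-c1nc(-c2ccccc2O)n(-c2ccc(F)cc2)n1` gives 67.2% in a functional assay on PC-12 cells (Rattus norvegicus) for cytotoxicity, read by MTT assay, with stated times of 2 h and 24 h, tested at 1 uM; a lower number here means a weaker effect, a higher number a stronger effect of the compound at the concentration tested. Its number sits between those of compound 3 `Oc1cc(C(F)(F)F)ccc1-c1nc(-c2ccccc2O)n(-c2ccc(Br)cc2)n1` at 69.4% and compound 1 `CCc1ccc(-n2nc(-c3ccc(C(F)(F)F)cc3O)nc2-c2ccccc2O)cc1` at 64.4%, both gaps within the scatter: a number 2.2 percentage points higher from compound 2 to compound 3 (within the scatter) and a number 2.8 percentage points higher from compound 1 to compound 2 (within the scatter).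

Compound 4 `Oc1cc(C(F)(F)F)ccc1-c1nc(-c2ccccc2O)n(-c2ccc(C(F)(F)F)cc2)n1` differs from compound 2 by trifluoromethyl in place of fluoro on an aromatic carbon. Every measured step exchanges the group at this same place: a number 2.8 percentage points higher from compound 1 to compound 2 (within the scatter), a number 5 percentage points higher from compound 1 to compound 3 (within the scatter), a number 2.2 percentage points higher from compound 2 to compound 3 (within the scatter), each within the scatter. None of them brings in trifluoromethyl, so the change is not covered directly, but three exchanges at this place left this assay flat, and no step beyond the scatter is expected here either. The estimate for compound 4 is 68%, range 58% to 78%, which means an expected step of a number 0.8 percentage points higher from compound 2 to compound 4 (within the scatter).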

Compound 4, a percentage reported as activity, at one concentration (the size of the read-out at that concentration, not a potency): 70.7%
The estimate for compound 4 lay 2.7 percentage points below the measured number; the range from low to high includes it.
By their numbers in this assay, from the lowest: compounds 1, 2, 3 and 4 (each within the scatter of the next).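

Trifluoromethyl on this aromatic carbon, para to a large group, leaves this assay as flat as the earlier exchanges did (steps: a number 3.5 percentage points higher from compound 2 to compound 4 (within the scatter); a number 1.3 percentage points higher from compound 3 to compound 4 (within the scatter); a number 6.3 percentage points higher from compound 1 to compound 4 (within the scatter)). Ethyl, fluoro, bromo and trifluoromethyl at this place now all stand within the scatter of one another, so a group of 4 heavy atoms separates no better here than the smaller ones. Nothing at hand explains this flatness.

From the compounds shown here alone, whether an amine or a carboxylic acid at this place would also stay within the scatter remains open.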